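Compound 2 to compound 3: carboxy group replaced

The source may report more compounds than this note shows. Statements on the series, on what has been measured and on what is new or still open speak of the compounds shown alone.

Two members of the series have been measured so far. In a functional assay on SW480 cells (Homo sapiens) for antiproliferative activity, read by MTT assay, with a stated time of 48 h (a higher number here means a weaker inhibitor, a lower number a stronger inhibitor), compound 1 (`CC(=O)O[C@]1(C)/C=C/C(=O)/C(CO)=C\C[C@](C)(CCC=C(C)C)/C=C/[C@H]1OC(=O)C=C(C)C`) gives 2010 nM as its value. Compound 2 (`CC(C)=CCC[C@]1(C)/C=C/[C@@H](OC(=O)C=C(C)C)[C@](C)(O)/C=C/C(=O)/C(C(=O)O)=C\C1`) reads > 10000 nM in the same test, and this is a limit of the assay, not a number. The next member is compound 3 (`CC[Si](CC)(CC)C/C1=C/C[C@](C)(CCC=C(C)C)/C=C/[C@@H](OC(=O)C=C(C)C)[C@](C)(O)/C=C/C1=O`), not yet measured in this assay at this stage. Its structural change from compound 2 is counted here (a group of 8 heavy atoms (7 carbon, 1 silicon; no ring) in place of a group of 3 heavy atoms (1 carbon, 2 oxygen; no ring), on a double-bonded ring carbon), and it falls on a double-bonded ring carbon. Among the measured compounds shown here, no measured pair isolates this change, so the expectation rests on thin ground. Compound 1, at 2010 nM in this series, shows that a numerical reading is possible, so a moderate gain in strength over compound 2 is expected. For compound 3, another reading at the limit of the assay remains possible. The expected change is an at least 2.5-fold lower number from compound 2 to compound 3 (0.39 log units; beyond the scatter) in this test. Compound 3 is expected at 4000 nM as a middle estimate. The estimated range for compound 3 runs from 1200 nM to 10000 nM for a single measurement.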

Compound 3, half-maximal inhibitory concentration: 2690 nM
Beside the measured number, compound 3's estimate is 1.5-fold (0.17 log units) above it, within the range that was stated.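

In this assay, among the compounds shown here, replacing the carboxy group with the group of 8 heavy atoms (7 carbon, 1 silicon) on the double-bonded ring carbon gives an at least 3.7-fold lower number from compound 2 to compound 3 (0.57 log units; beyond the scatter), the first step that isolates a single place. The entering group carries no hydrogen-bond donor or acceptor, so neither is required at this ring carbon for a numerical reading in this test, and a group with silicon and more heavy atoms is compatible with one. The true size of the step cannot be given because the reading for compound 2 is a limit of the assay and not a number: the limit of > 10000 nM in this assay, at which 1 of the 3 values shown sits.

The compounds shown do not separate the departure of the carboxy group from the arrival of the silicon-bearing group, so it remains open which of the two accounts for the step. As far as these compounds go, it also remains open whether a methyl ester, a primary amide or a longer all-carbon chain on the same ring carbon would give a reading like that of compound 3, or whether the silicon atom matters at all.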